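Working notes: from compound 3 to compound 4

A few compounds are considered here, and "the series" means these few. Any claim that something is new, unique, unknown or untested is made for them only; others in the source may bear on it.

Measured so far in a functional assay on MC-38 cells (Mus musculus) for antiproliferative activity, read by CCK-8 assay, with a stated time of 48 h; a lower number here means a stronger inhibitor, a higher number a weaker inhibitor
- compound 1 `COc1ccc(/C=C\c2cc(OC)c(OC)c(OC)c2)cc1OCc1ccc(CO)cc1` gives 5700 nM
- compound 2 `COc1ccc(/C=C\c2cc(OC)c(OC)c(OC)c2)cc1OCc1ccc(CN2CC(C(=O)O)C2)cc1` gives > 10000 nM which is a limit of the assay and not a number
- compound 3 `COc1ccc(/C=C\c2cc(OC)c(OC)c(OC)c2)cc1OCc1ccc(CN2CC[C@H](O)C2)cc1` gives 7200 nM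

Compound 3 stands close to compound 1, with a 1.3-fold higher number from compound 1 to compound 3 (0.10 log units; within the scatter) in this assay and so no order between the two. Against compound 2 the comparison gives only a floor, an at least 1.3-fold lower number from compound 2 to compound 3 (0.14 log units; that floor lies within the scatter) on that side.

The next change leads to compound 4 `COc1ccc(/C=C\c2cc(OC)c(OC)c(OC)c2)cc1OCc1ccc(CN[C@H](C(=O)O)[C@@H](C)O)cc1` and reads ((1-carboxy-2-hydroxypropyl)amino in place of 3-hydroxypyrrolidin-1-yl on a saturated chain carbon bound to an aromatic carbon). In words, (1-carboxy-2-hydroxypropyl)amino stands in place of 3-hydroxypyrrolidin-1-yl on a saturated chain carbon bound to an aromatic carbon.

For the measured compounds named here, two measured steps bear on this change. Compound 3 shows that an amine-linked replacement of the hydroxy group moved the value only within the scatter (a 1.3-fold higher number from compound 1 to compound 3 (0.10 log units; within the scatter)). Going by the values given here, compound 2 is the only measured compound with a carboxy-bearing group, and its step is again only a floor (an at least 1.7-fold higher number from compound 1 to compound 2 (0.24 log units; that floor lies within the scatter)). A small move to a higher number is therefore expected, not clearly beyond the scatter, and a reading at the limit of the assay would fit.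

The expected step is a 1.4-fold higher number from compound 3 to compound 4 (0.14 log units; within the scatter) in this assay as an estimate.

The estimated value for compound 4 is 10000 nM with an expected range from 5000 nM to 20000 nM (in this assay).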

Compound 4, half-maximal inhibitory concentration: > 10000 nM
Compound 4: a limit, no number (the forecaster's own chance of this, stated with the estimate: 45%); the middle value sits exactly at the limit.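

In this assay compound 4 reads > 10000 nM, which is a limit of the assay and not a number. A second carboxy-bearing group on a saturated chain carbon bound to an aromatic carbon, now the open-chain (1-carboxy-2-hydroxypropyl)amino in place of a ring, gives the same reading as compound 2: the limit of > 10000 nM in this assay, at which 2 of the 4 values shown sit. The steps give only floors, an at least 1.3-fold higher number from compound 3 to compound 4 (0.14 log units; that floor lies within the scatter) and an at least 1.7-fold higher number from compound 1 to compound 4 (0.24 log units; that floor lies within the scatter), so neither is shown to lie beyond the scatter, and the step between the two carboxy-bearing compounds cannot be read.

Without a number for compound 2 or compound 4, the ring and open-chain carboxy-bearing groups cannot be ranked, and no separate contribution can be assigned to the carboxylic acid, the extra hydroxy group or the loss of the ring. A methyl ester in place of the carboxylic acid, or a simple dimethylamino group at this place, would test whether a reading below the limit returns in this assay.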